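The compounds below may be only part of what the source reports. "The series", "measured", "known", "first", "only" and "open" are said of these compounds alone.

Measured so far in an ADME assay on L6 cells (Rattus norvegicus) for cytotoxicity; on this read-out higher numbers stand for weaker inhibition and lower numbers for stronger inhibition
- compound 1 `O=C(CCN1CCCC1)OC1CC2(N3CCCCC3)CC(c3ccccc3)C1C(c1ccccc1)C2` gives 12500 nM
- compound 2 `O=C(CN1CCC(O)CC1)OC1CC2(N3CCCC3)CC(c3ccccc3)C1C(c1ccccc1)C2` gives 93400 nM

Of the two, compound 2 stands higher, and the gap to compound 1 lies beyond the usual scatter. Going by the values given here, compound 2 is thus the weaker inhibitor in this assay so far.

Compound 3 `O=C(CN1CCC(O)CC1)OC1CC2(N3CCCCC3)CC(c3ccccc3)C1C(c1ccccc1)C2` departs from compound 2 in a single place, with piperidin-1-yl in place of pyrrolidin-1-yl on a saturated ring carbon and everything else unchanged. Among the compounds with values here, no measured pair isolates this exchange, so the expectation rests on little. Within the data shown here, a modest move towards lower numbers is expected, probably not clearly beyond the scatter, and compound 1 at 12500 nM shows only that lower numbers occur in this small set. The estimated step is a 1.7-fold lower number from compound 2 to compound 3 (0.23 log units; within the scatter) in this assay and no larger move is assumed. For compound 3 the expected value is 55000 nM within an estimated range of 18000 nM to 140000 nM for repeated measurements.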

Compound 3, half-maximal inhibitory concentration: > 179000 nM
Compound 3 gave a limit, no number; the forecaster's own chance of this, stated with the estimate: 10%; at least 3.2-fold (0.51 log units) between middle value and limit.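

In this assay compound 3 gives a limit and no number: the limit of > 179000 nM in this assay, at which 1 of the 3 values shown sits. The exchange of pyrrolidin-1-yl for piperidin-1-yl on the saturated ring carbon now has a measured pair, which gives an at least 1.9-fold higher number from compound 2 to compound 3 (0.28 log units; that floor lies within the scatter), so the floor of this step does not by itself separate the two compounds. The change of (pyrrolidin-1-yl)methyl to 4-hydroxypiperidin-1-yl on the saturated chain carbon bound to a carbonyl carbon gives an at least 14-fold higher number from compound 1 to compound 3 (1.15 log units; beyond the scatter), a clear move towards higher numbers.

From the compounds shown here alone, the full size of both steps remains open, as does how a morpholin-4-yl or dimethylamino group would read on the same ring carbon. Going by these compounds, it is also open whether the step at the chain carbon would persist with plain piperidin-1-yl in place of 4-hydroxypiperidin-1-yl.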